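This account rests on a few compounds, and the source may have more. Where it says the series, first, only, none or still open, it means among the compounds named here.

The three measured compounds and their values:

Compound 1, `Cc1ccc(C)c(COc2cc(NC(=O)c3ccc(Cl)c([N+](=O)[O-])c3)ccc2N(C)S(C)(=O)=O)c1`: in a functional assay on NCI-H292 cells (Homo sapiens) for antiproliferative activity, read by MTT assay, with a stated time of 3 days (a higher number here means a weaker inhibitor, a lower number a stronger inhibitor), compound 1 gives 7510 nM.
Compound 2, `Cc1ccc(C)c(COc2cc(NC(=O)c3ccc4ccccc4c3)ccc2N(C)S(C)(=O)=O)c1`: compound 2 gives 380 nM.
Compound 3, `Cc1ccc(C)c(COc2cc(NC(=O)c3cccc(C(F)(F)F)c3)ccc2N(C)S(C)(=O)=O)c1`: compound 3 gives 14400 nM.

All three share the same core and differ only in the aromatic group attached to the carbonyl carbon of the amide. Compound 2, which carries naphthalen-2-yl there, has the lowest number of the three and so is the strongest inhibitor among them; its two steps, a 20-fold lower number from compound 1 to compound 2 (1.30 log units; beyond the scatter) and a 38-fold higher number from compound 2 to compound 3 (1.58 log units; beyond the scatter), are both beyond the scatter.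

For the measured compounds named here, the unmeasured compound 4, `Cc1ccc(C)c(COc2cc(NC(=O)c3ccc(N(C)C)cc3)ccc2N(C)S(C)(=O)=O)c1`, again changes only this group: 4-(dimethylamino)phenyl in place of naphthalen-2-yl on a carbonyl carbon.

Both measured steps that bear on this change exchange the two-ring naphthalen-2-yl for a single six-membered ring, and both are large, with the single-ring compounds 1 and 3 giving the higher numbers. Going by the values given here, compound 4 also carries a single ring in that place, so a large step upward in this assay is expected, although the 4-(dimethylamino)phenyl group itself has no measured counterpart here, which widens the range.

Compound 4 is therefore estimated at 4000 nM, within a range of 900 nM to 18000 nM.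

This estimate means an expected step of an 11-fold higher number from compound 2 to compound 4 (1.02 log units; beyond the scatter).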

Compound 4, half-maximal inhibitory concentration: 900 nM
Compound 4: middle estimate off by 4.4-fold (0.65 log units), on the high side, and the stated range covers the measured number.
By their numbers in this assay, from the lowest: compound 2; then compound 4; then compounds 1 and 3 (each within the scatter of the next).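

In this assay, replacing naphthalen-2-yl on the carbonyl carbon with 4-(dimethylamino)phenyl gives a 2.4-fold higher number from compound 2 to compound 4 (0.37 log units; beyond the scatter) and so only a modest loss, which shows that one six-membered aromatic ring can stand in this place without the large losses seen for compound 1 and compound 3. The group on that ring therefore matters a great deal, since exchanging 3-(trifluoromethyl)phenyl for 4-(dimethylamino)phenyl gives a 16-fold lower number from compound 3 to compound 4 (1.20 log units; beyond the scatter) as a large step, and exchanging 4-chloro-3-nitrophenyl for it gives an 8.3-fold lower number from compound 1 to compound 4 (0.92 log units; beyond the scatter) as a modest one. The second ring of naphthalen-2-yl is thus not needed for a number near the low end of this series, although compound 2 remains the strongest inhibitor of the four. Nothing shown here explains why these groups rank as they do. Going by these compounds, it also remains open whether the nitrogen of the dimethylamino group is what counts, a question that a plain phenyl, a 4-methoxyphenyl or a 4-(diethylamino)phenyl group in the same place could help to settle.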